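The compounds below may be only part of what the source reports. "The series", "measured", "known", "first", "only" and "open" are said of these compounds alone.

Working notes on the series. In an assay on isolated protein for inhibition of serine/threonine-protein kinase TNNI3K (Homo sapiens) (a lower number here means a stronger inhibitor, a higher number a weaker inhibitor), compound 1 `Nc1cc(Oc2ccc(NC(=O)Nc3cccc(C(F)(F)F)c3)cc2)ncn1` gives 25 nM. Compound 2 `CCNc1cc(Oc2ccc(NC(=O)Nc3cccc(C(F)(F)F)c3)cc2)ncn1` gives 25 nM in this assay; the step of no change at the digits printed from compound 1 to compound 2 (within the scatter) is ethyl in place of hydrogen on a nitrogen on an aromatic ring. Compound 3 `Cc1cc(Oc2ccc(NC(=O)Nc3cccc(C(F)(F)F)c3)cc2)ncn1` gives 160 nM in this assay, the highest of the three numbers, separated from both others by steps beyond the scatter: a 6.4-fold higher number from compound 1 to compound 3 (0.81 log units; beyond the scatter) and a 6.4-fold higher number from compound 2 to compound 3 (0.81 log units; beyond the scatter), both modest and both upward.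

Compound 4 `O=C(Nc1ccc(Oc2ccncc2)cc1)Nc1cccc(C(F)(F)F)c1` differs from compound 3 by pyridin-4-yl in place of 6-methylpyrimidin-4-yl on an oxygen on an aromatic ring. Among the compounds with values here, no measured step exchanges the ring bound through the oxygen; the measured steps only alter the group on that ring, and they show that changes there move the number modestly at most. Within the data shown here, that is the only guide, so the expectation is weak. The expected step is a 1.1-fold lower number from compound 3 to compound 4 (0.03 log units; within the scatter), which may well sit within the scatter. Compound 4 is expected to give 150 nM in this assay, with a range from 30 nM to 800 nM.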

Compound 4, half-maximal inhibitory concentration: 50 nM
Beside the measured number, compound 4's estimate is 3.0-fold (0.48 log units) above it; measured number inside the range.
By their numbers in this assay, from the lowest: compounds 1, 2 and 4 (each within the scatter of the next); then compound 3.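

Exchanging the ring bound through the oxygen does move the number in this assay (a 3.2-fold lower number from compound 3 to compound 4 (0.51 log units; beyond the scatter)), so this position responds to more than the group carried on the ring. The comparisons with the amino compounds (a 2.0-fold higher number from compound 1 to compound 4 (0.30 log units; within the scatter); a 2.0-fold higher number from compound 2 to compound 4 (0.30 log units; within the scatter)) show that pyridin-4-yl, which carries no amino group, cannot be told apart from 6-aminopyrimidin-4-yl or 6-(ethylamino)pyrimidin-4-yl, so a number in this range does not depend on an amino group at this place. Nothing available explains these results.

The change from 6-methylpyrimidin-4-yl to pyridin-4-yl removes the methyl and one ring nitrogen together, so the share of each remains unresolved. Also open, going by these compounds, is how a 2-aminopyridin-4-yl, a 2-methylpyridin-4-yl or a plain phenyl ring would read on the same oxygen.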